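This account rests on a few compounds, and the source may have more. Where it says the series, first, only, none or still open, it means among the compounds named here.

Measured so far:
compound 1, `CCOCC(Oc1c(C)cccc1Cl)N1CCN(c2ccccc2OC)CC1` — 34 nM
compound 2, `Clc1ccc(-c2nn(Cc3ccccc3)c3c2CCNCC3)cc1` — 3 nM

In an assay on isolated protein for binding affinity to 5-hydroxytryptamine receptor 7 (Homo sapiens) (on this read-out lower numbers stand for stronger inhibition and higher numbers for weaker inhibition), compound 1 gives 34 nM, the higher of the two numbers; compound 2 gives 3 nM, a gap that lies beyond the usual scatter. Compound 3, `CCOCC(Oc1c(C)cccc1C)N1CCN(c2ccccc2OC)CC1`, differs from compound 1 by methyl in place of chloro on an aromatic carbon. For the measured compounds named here, no measured pair shows this change, and nothing here points in either direction; the step of a 1.2-fold higher number from compound 1 to compound 3 (0.07 log units; within the scatter) is therefore expected to stay within the scatter. Compound 3 is estimated at 40 nM, with a range from 15 nM to 110 nM.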

Compound 3, inhibition constant: 156 nM
Beside the measured number, compound 3's estimate is 3.9-fold (0.59 log units) below it; measured number outside the range, above it.
By their numbers in this assay, from the lowest: compound 2; then compound 1; then compound 3.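

In this assay, replacing 2-chloro-6-methylphenoxy with 2,6-dimethylphenoxy gives a 4.6-fold higher number from compound 1 to compound 3 (0.66 log units; beyond the scatter), so this aromatic position is sensitive to methyl in place of chloro. For the compounds shown here, this is the only single-place comparison so far, and it favours chloro over methyl on this one pair alone. Nothing on hand accounts for the step. Going by these compounds, whether fluoro, methoxy or nitrile at this position would give a lower or higher number remains open, as does whether the step holds when the remaining methyl on that ring is changed.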